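Notes on the step from compound 1 to compound 4

This account rests on a few compounds, and the source may have more. Where it says the series, first, only, none or still open, it means among the compounds named here.

Compound 1 is `Cc1cc(C(=O)NCc2ccncc2)nn1Cc1cc(Cl)ccc1OCc1ccccc1`. In a physicochemical assay for lipophilicity, at pH 7.4 (a lower number here means a more polar compound, a higher number a more lipophilic compound), compound 1 gives > 3.7, which is a limit of the assay and not a number. Compound 2 is `Cc1cc(C(=O)NN2CCOCC2)nn1Cc1cc(Cl)ccc1OCC(C)C` and in this assay compound 2 gives 3.1. Compound 3 is `Cc1cc(NC(=O)CC(C)(C)C)nn1Cc1cc(Cl)ccc1OCc1ccccc1`. In this assay compound 3 gives > 3.7, again a limit of the assay. Compound 1 therefore stands at the limit, where (the limit of > 3.7 in this assay, at which 2 of the 3 values shown sit).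

For the measured compounds named here, only one measured step bears on the change to compound 4, the step that the two limits leave unreadable from compound 1 to compound 3, and since both of its ends are limits its size and direction cannot be read. Compound 4 is `COC(=O)Nc1cc(C)n(Cc2cc(Cl)ccc2OCc2ccccc2)n1`; it differs from compound 1 as follows: (methoxycarbonyl)amino in place of ((pyridin-4-yl)methyl)carbamoyl on an aromatic carbon.

No readable step is available, so no direction beyond the scatter can be expected with confidence; the change is expected to leave compound 4 near the limit at which compound 1 sits. Compound 4 is estimated at 3.9 in this assay, within a range from 3.3 to 4.5. The expected step that the limit leaves unreadable from compound 1 to compound 4 is reckoned from a limit and is therefore only an indication, and a further limit is considered about as likely as a number.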

Compound 4, distribution coefficient: > 3.7
Compound 4: no number, only a limit; the forecaster's own chance of this, stated with the estimate: 55%; the middle value is on the limit's open side.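

In this assay compound 4 gives > 3.7, a limit of the assay and not a number. The steps joining compound 4 to compound 1 and to compound 3 both run between limits and cannot be read: the limit of > 3.7 in this assay, at which 3 of the 4 values shown sit. The compounds shown leave open whether compound 1, compound 3 and compound 4 differ at all in this assay.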